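A few compounds are considered here, and "the series" means these few. Any claim that something is new, unique, unknown or untested is made for them only; others in the source may bear on it.

Measured compounds:
compound 1 `COc1ccccc1CNc1ncnc2c1ncn2C1CCCCO1` — > 100000 nM, a limit of the assay
compound 2 `COc1cccc(OC)c1CNc1ncnc2c1ncn2C1CCCCO1` — > 100000 nM, a limit of the assay
compound 3 `COc1cc(CNc2ncnc3c2ncn3C2CCCCO2)cc(OC)c1` — > 100000 nM, a limit of the assay

In an ADME assay on BJ cells (Homo sapiens) for cytotoxicity, read by MTT assay, with a stated time of 72 h (a lower number here means a stronger inhibitor, a higher number a weaker inhibitor), compound 1 gives > 100000 nM, a limit rather than a number. Compound 2 likewise gives only a limit, > 100000 nM. The change methoxy in place of hydrogen on an aromatic carbon gives a step that the two limits leave unreadable from compound 1 to compound 2; both values sit at the limit of > 100000 nM in this assay, at which 3 of the 3 values shown sit. Compound 3 also gives only a limit, > 100000 nM. The difference between the core of compound 1 and the core of compound 3 is not broken down here.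

Compound 4 `COc1cc(CNc2ncnc3c2ncn3C2CCCCO2)cc(OC)c1OC` is not yet measured; it differs from compound 3 by methoxy in place of hydrogen on an aromatic carbon, the same kind of change as that made from compound 1 to compound 2, though the place differs: there it is ortho to a large group and meta to a methoxy group, here ortho to two methoxy groups and para to a large group. The step is expected to be a number no higher from compound 3 to compound 4 (the limit leaves the size open), resting on compound 1 and compound 2 where a step that the two limits leave unreadable from compound 1 to compound 2 and all three values sit at the limit of > 100000 nM in this assay, at which 3 of the 3 values shown sit. Compound 4 is expected to give 100000 nM, estimated between 50000 nM and 200000 nM.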

Compound 4, half-maximal inhibitory concentration: > 100000 nM
Compound 4: only a limit was reported (the forecaster's own chance of this, stated with the estimate: 85%); the middle value sits exactly at the limit.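

In this assay compound 4 gives > 100000 nM, a limit and not a number. Among these compounds, compound 3 also has only a limit, so no step between compound 3 and compound 4 can be read. The compounds shown leave open whether methoxy in place of hydrogen on an aromatic carbon changes this read-out at all.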